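A few compounds are considered here, and "the series" means these few. Any claim that something is new, unique, unknown or untested is made for them only; others in the source may bear on it.

Compound 1, `O=c1cc(-c2ccccc2)ncn1CCCCCN1CCN(c2cccc(Cl)c2)CC1`: 94.7 nM
Compound 2, `c1ccc(-c2cc(OCCCCCN3CCN(c4ccccc4)CC3)ncn2)cc1`: 143 nM
Compound 3, `Clc1ccc(N2CCN(CCCCCOc3cc(-c4ccccc4)ncn3)CC2)cc1`: 1380 nM

All three compounds were tested in an assay on CHO-K1 cells for displacement of a labelled ligand from 5-hydroxytryptamine receptor 7 (Homo sapiens), read by scintillation counting, with a stated time of 40 min; on this read-out lower numbers stand for stronger inhibition and higher numbers for weaker inhibition. Compound 3 gives the highest number of the three: compound 2 sits at a lower number, and compound 1 at a lower number still, so compound 3 is the weakest binder among the compounds measured. For the measured compounds named here, the only step between two measured compounds that differ in a single place is a 9.7-fold higher number from compound 2 to compound 3 (0.98 log units; beyond the scatter), which came with chloro in place of hydrogen on an aromatic carbon.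

Compound 4, `CCOc1ccccc1N1CCN(CCCCCOc2cc(-c3ccccc3)ncn2)CC1`, differs from compound 3 by 2-ethoxyphenyl in place of 4-chlorophenyl on an amine nitrogen in a ring. This change removes the chloro again, which on its own points back toward the number of compound 2, since the step from compound 2 to compound 3 was the addition of that chloro. Going by the values given here, the ethoxy group that enters, however, has no counterpart among the measured compounds, so its effect cannot be read from the data. The expectation is therefore a downward step of an 11-fold lower number from compound 3 to compound 4 (1.03 log units; beyond the scatter) in this assay, with wide uncertainty around it. Compound 4 is estimated at 130 nM, with a likely range from 30 nM to 550 nM.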

Compound 4, inhibition constant: 23.5 nM
Estimate against measurement, compound 4: 5.5-fold (0.74 log units) above, outside the stated range (below it).
By their numbers in this assay, from the lowest: compound 4; then compounds 1 and 2 (each within the scatter of the next); then compound 3.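

In this assay the aromatic ring on the ring nitrogen proves to be a place where a change can pay off strongly: putting 2-ethoxyphenyl in place of 4-chlorophenyl gives a 59-fold lower number from compound 3 to compound 4 (1.77 log units; beyond the scatter) in this series. Compound 2, whose ring carries no substituent, separates the gain from the mere loss of the chloro: adding the ethoxy gives a 6.1-fold lower number from compound 2 to compound 4 (0.78 log units; beyond the scatter), so a substituent on this ring can lower the number as well as raise it, which the chloro of compound 3 alone could not show. No measurement at hand explains why these two groups pull in opposite directions.

Chloro and ethoxy also sit at different places on the ring, so these compounds cannot separate the identity of the group from its position; 2-chlorophenyl, 4-ethoxyphenyl or 2-methoxyphenyl would be needed to pull the two apart. Going by these compounds, it also remains open whether the 2-ethoxyphenyl group would give a similar step on the core of compound 1, which differs from the others in more than one place.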